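Three aryl analogues on a shared core and a fourth

This account rests on a few compounds, and the source may have more. Where it says the series, first, only, none or still open, it means among the compounds named here.

The series rests on one core carrying a substituted phenyl on an amide-type nitrogen. Compound 1 `Cc1cccc(NC(=S)N/N=C/c2ccc3ccccc3n2)c1` bears a 3-methylphenyl there. In a functional assay on SGC-7901 cells (Homo sapiens) for antiproliferative activity, read by sulforhodamine B assay, with a stated time of 72 h (on this read-out lower numbers stand for stronger inhibition and higher numbers for weaker inhibition), compound 1 reaches only the limit of the assay, > 100000 nM. Compound 2 `S=C(N/N=C/c1ccc2ccccc2n1)Nc1cccc(Br)c1` differs by bromo in place of methyl on an aromatic carbon; in this assay compound 2 gives 78600 nM. The step of an at least 1.2-fold lower number from compound 1 to compound 2 (0.10 log units; that floor lies within the scatter) is thus modest. Compound 3 `Cc1ccccc1NC(=S)N/N=C/c1ccc2ccccc2n1` is built from the same atoms as compound 1, joined differently: 2-methylphenyl in place of 3-methylphenyl on an amide-type nitrogen. In this assay compound 3 also sits at the limit of the assay, > 100000 nM. Hence the step that the two limits leave unreadable from compound 1 to compound 3 cannot be read, while an at least 1.2-fold higher number from compound 2 to compound 3 (0.10 log units; that floor lies within the scatter) is small; both compound 1 and compound 3 sit at the same ceiling, as the limit of > 100000 nM in this assay, at which 2 of the 3 values shown sit, records.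

Compound 4 `S=C(N/N=C/c1ccc2ccccc2n1)Nc1ccccc1Br` has not yet been measured in this assay. It differs from compound 3 by bromo in place of methyl on an aromatic carbon. This is the same kind of change as that from compound 1 to compound 2, but the place differs: there the bromo sits "meta to a large group", here "ortho to a large group". Since the earlier step of an at least 1.2-fold lower number from compound 1 to compound 2 (0.10 log units; that floor lies within the scatter) stayed within the scatter and compound 3 already rests at the limit, the step of an at least 1.1-fold lower number from compound 3 to compound 4 (0.04 log units; that floor lies within the scatter) is expected to be of similar, small size. Compound 4 is therefore estimated at 90000 nM, within 40000 nM and 200000 nM, with a real chance that the assay again reports only a limit.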

Compound 4, half-maximal inhibitory concentration: > 100000 nM
Compound 4 was reported as a limit; the forecaster's own chance of this, stated with the estimate: 55%; middle value at least 1.1-fold (0.04 log units) away from the limit.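

In this assay compound 4 gives > 100000 nM, which is a limit of the assay and not a number. Among these compounds, neither the step to compound 4 from compound 3 nor the one to it from compound 1 can be read, because these three compounds rest at one ceiling: the limit of > 100000 nM in this assay, at which 3 of the 4 values shown sit. The only step that can be read is an at least 1.2-fold higher number from compound 2 to compound 4 (0.10 log units; that floor lies within the scatter), and since it is only a floor within the scatter, it gives no order between the two bromophenyl compounds; thus the swap of methyl for bromo, seen as an at least 1.2-fold lower number from compound 1 to compound 2 (0.10 log units; that floor lies within the scatter), is neither confirmed nor ruled out when it is carried to the place ortho to a large group.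

Compound 2 is the only one of the four with a number rather than a limit, so the compounds shown leave open how far any change on this phenyl can move the read-out within the range of the assay. They also leave open whether an amine or a carboxylic acid on the phenyl, or a longer chain in place of the bromo, would give a value that can be compared at all.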